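This account rests on a few compounds, and the source may have more. Where it says the series, first, only, none or still open, it means among the compounds named here.

In a functional assay on HL-60 cells (Homo sapiens) for antiproliferative activity, read by MTT assay, with a stated time of 24 h (a higher number here means a weaker inhibitor, a lower number a stronger inhibitor), compound 1 `Cc1cccc(Nc2ncc(Br)c(Oc3cccc(F)c3)n2)c1` gives 15500 nM and compound 3 `Cc1cccc(Nc2ncc(Br)c(Oc3ccc(Br)cc3)n2)c1` gives 14700 nM. Compound 2 `Cc1cccc(Nc2ncc(Br)c(Oc3cc(Cl)cc(Cl)c3)n2)c1` reaches only the limit of > 50000 nM in this assay. Compound 3 thus stands at the lower of the two numbers, though the step of a 1.1-fold lower number from compound 1 to compound 3 (0.02 log units; within the scatter) lies within the scatter, while the step of an at least 3.4-fold lower number from compound 2 to compound 3 (0.53 log units; beyond the scatter) lies beyond it. Compound 4 `Cc1cccc(Nc2ncc(Br)c(Oc3ccc(OCc4ccccc4)cc3)n2)c1` differs from compound 3 by benzyloxy in place of bromo on an aromatic carbon. Among the measured compounds shown here, no measured step introduces a benzyloxy group; the steps among compounds 1, 2 and 3 exchange halogens on the aryl group on the oxygen, and an at least 3.2-fold higher number from compound 1 to compound 2 (0.50 log units; beyond the scatter) shows that such an exchange can push a number to the limit. For compound 4 a step of a 1.4-fold higher number from compound 3 to compound 4 (0.13 log units; within the scatter) in this assay is therefore expected, with little confidence. The estimate for compound 4 is 20000 nM, between 8000 nM and 50000 nM.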

Compound 4, half-maximal inhibitory concentration: > 50000 nM
Compound 4: only a limit was reported (the forecaster's own chance of this, stated with the estimate: 25%); middle value at least 2.5-fold (0.39 log units) from the limit.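

The step of an at least 3.4-fold higher number from compound 3 to compound 4 (0.53 log units; beyond the scatter) in this assay shows that bromo on this aromatic carbon cannot be exchanged for benzyloxy without a change beyond the scatter. Among the earlier compounds, only halogen exchanges had been seen, and only compound 2 had reached the top of the range. Compound 4 gives only a limit, so the full size of this step stays unknown, and it shares that limit with compound 2: the limit of > 50000 nM in this assay, at which 2 of the 4 values shown sit.

The compounds shown leave open whether methoxy or an amine on this carbon would stay near compound 3 14700 nM. They also leave open whether the oxygen or the added phenyl ring accounts for the step.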